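A few compounds are considered here, and "the series" means these few. Any claim that something is new, unique, unknown or untested is made for them only; others in the source may bear on it.

Working notes on the series. Compound 1 `CCOC(=O)CCO/N=C(/c1ccc(OC)c(OC)c1OC)c1cccc2ccccc12` is one of two measured members. In a functional assay on THP-1 cells (Homo sapiens) for inhibition, read by sulforhodamine B assay, with a stated time of 48 h (a lower number here means a stronger inhibitor, a higher number a weaker inhibitor), compound 1 gives > 20000 nM, which is a limit of the assay and not a number. Compound 2 `COc1ccc(C(O)(Cc2ccc(C)cc2)c2cccc3ccccc23)c(OC)c1OC` shares the core. In this assay compound 2 gives > 20000 nM, likewise only a limit. For the measured compounds named here, both measured values therefore rest at the limit of > 20000 nM in this assay, at which 2 of the 2 values shown sit, so for compound 1 nothing more than a limit is known and no step between measured compounds can be drawn. Compound 3 `COc1ccc(/C(=N/OCC(=O)O)c2cccc3ccccc23)c(OC)c1OC` is the unmeasured analogue of compound 1; the change is carboxy in place of (ethoxycarbonyl)methyl on a saturated chain carbon bound to an oxygen on an unsaturated carbon. Going by the values given here, with no measured step to lean on, the expected movement is a step that the limit leaves unreadable from compound 1 to compound 3, that is none beyond the scatter. Compound 3 is accordingly expected at 25000 nM, with a range from 8000 nM to 80000 nM, and most probably it will again be reported only as a limit.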

Compound 3, half-maximal inhibitory concentration: > 20000 nM
Compound 3 ended at the assay's limit; the forecaster's own chance of this, stated with the estimate: 75%; the middle value is on the limit's open side.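

Compound 1 and compound 3 both rest at a limit of the assay and not at a number in this assay, so no step between them can be read: the limit of > 20000 nM in this assay, at which 3 of the 3 values shown sit.

The compounds shown leave open whether carboxy in place of (ethoxycarbonyl)methyl changes inhibition at all, and which change on the shared core would bring a value inside the range of this assay.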